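Chlorofuran Replaces Furan in a Series of Level Read-outs

The source may report more compounds than this note shows. Statements on the series, on what has been measured and on what is new or still open speak of the compounds shown alone.

Of the compounds shown here, three sharing one core have been tested in an assay on isolated protein for inhibition of DNA topoisomerase 1 (Homo sapiens), with a stated time of 30 min, tested at 100 uM; on this read-out lower numbers stand for less inhibition and higher numbers for more inhibition at the one concentration tested (going by the name of the read-out). Compound 2, `Clc1ccc(-c2cc(-c3ccoc3)cc(-c3ccc(Cl)s3)n2)cc1`, gives 2.3%. Compound 3, `Clc1ccc(-c2cc(-c3ccoc3)cc(-c3cccnc3)n2)s1`, gives 2%, and compound 1, `Cc1ccc(-c2cc(-c3ccoc3)cc(-c3ccc(Cl)s3)n2)cc1`, gives 0%. Every step among them lies within the scatter: a number 2.3 percentage points higher from compound 1 to compound 2 (within the scatter), a number 2 percentage points higher from compound 1 to compound 3 (within the scatter) and a number 0.3 percentage points lower from compound 2 to compound 3 (within the scatter), so compound 2 stands apart from neither of the others.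

Compound 4, `Clc1ccc(-c2cc(-c3ccc(Cl)o3)cc(-c3ccc(Cl)s3)n2)cc1`, is obtained from compound 2 by the change (5-chlorofuran-2-yl in place of furan-3-yl on an aromatic carbon). For the measured compounds named here, no measured step touches this position; the steps that do exist, a number 2.3 percentage points higher from compound 1 to compound 2 (within the scatter) and a number 0.3 percentage points lower from compound 2 to compound 3 (within the scatter), show that exchanging groups elsewhere on the core leaves this assay unchanged, and the read-out of compound 2 lies near zero, so there is little room for any fall.

Compound 4 is therefore expected to give 3% in this assay, estimated between 0% and 15%, an expected step of a number 0.7 percentage points higher from compound 2 to compound 4 (within the scatter) that stays within the scatter.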

Compound 4, a percentage reported as inhibition, at one concentration (the size of the read-out at that concentration, not a potency): 2.2%
Beside the measured number, compound 4's estimate is 0.8 percentage points above it, and the stated range covers the measured number.
By their numbers in this assay, from the lowest: compounds 1, 3, 4 and 2 (each within the scatter of the next).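

At the position opposite the ring nitrogen, the first change measured there, 5-chlorofuran-2-yl in place of furan-3-yl, gives in this assay a number 0.1 percentage points lower from compound 2 to compound 4 (within the scatter). This position therefore joins the changes made elsewhere on the shared core: none of the listed steps leaves the scatter, even though this one swaps a furan-3-yl for a furan-2-yl and adds a chlorine at once. Nothing available bears on why the read-out stays where it is.

With both changes combined in one step, the compounds shown cannot separate the effect of the chlorine from that of the furan's point of attachment. On these data alone, whether an amine or a carboxylic acid at this position would carry the read-out beyond the scatter also remains open.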